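Trifluoromethyl in place of a methoxyethyl chain

The compounds below may be only part of what the source reports. "The series", "measured", "known", "first", "only" and "open" are said of these compounds alone.

In a functional assay on MCF7 cells (Homo sapiens) for cytotoxicity, read by CellTiter-Glo, with a stated time of 5 days (a lower number here means a stronger inhibitor, a higher number a weaker inhibitor), compound 2 `COCC/C(=C(/c1ccc(/C=C/C(=O)O)cc1)c1ccc2[nH]ncc2c1)c1ccccc1` gives 63 nM, the highest number among the three measured compounds. Compound 1 `CCCC/C(=C(/c1ccc(/C=C/C(=O)O)cc1)c1ccc2[nH]ncc2c1)c1ccccc1` gives 10 nM and compound 3 `O=C(O)/C=C/c1ccc(/C(=C(\c2ccccc2)C(F)F)c2ccc3[nH]ncc3c2)cc1` gives 14 nM. Compound 4 `O=C(O)/C=C/c1ccc(/C(=C(\c2ccccc2)C(F)(F)F)c2ccc3[nH]ncc3c2)cc1` differs from compound 2 by trifluoromethyl in place of 2-methoxyethyl on a double-bonded chain carbon bound to an aromatic carbon and a double-bonded chain carbon. The closest measured comparison is the step of a 4.5-fold lower number from compound 2 to compound 3 (0.65 log units; beyond the scatter), where difluoromethyl entered the same place. The step of a 1.4-fold higher number from compound 1 to compound 3 (0.15 log units; within the scatter) shows that butyl and difluoromethyl there give numbers that cannot be told apart, while the step of a 6.3-fold higher number from compound 1 to compound 2 (0.80 log units; beyond the scatter) shows how much the 2-methoxyethyl chain raises the number. A drop of similar size to that seen with difluoromethyl is therefore expected, a 4.5-fold lower number from compound 2 to compound 4 (0.65 log units; beyond the scatter). Compound 4 is estimated at 14 nM, within a range from 5 nM to 40 nM.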

Compound 4, half-maximal inhibitory concentration: 5.5 nM
Estimate against measurement, compound 4: 2.5-fold (0.41 log units) above; the measured number falls inside the stated range.
By their numbers in this assay, from the lowest: compounds 4, 1 and 3 (each within the scatter of the next, the first and the last beyond it); then compound 2.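

In this assay, trifluoromethyl at this place goes beyond what difluoromethyl reached: the full swap for 2-methoxyethyl gives a large step (an 11-fold lower number from compound 2 to compound 4 (1.06 log units; beyond the scatter)), and the one added fluoro on its own gives a further step beyond the scatter (a 2.5-fold lower number from compound 3 to compound 4 (0.41 log units; beyond the scatter)). Butyl and trifluoromethyl still cannot be told apart here (a 1.8-fold lower number from compound 1 to compound 4 (0.26 log units; within the scatter)), so a chain is not needed for a low number. On these data alone, whether an amine or a longer chain ending in a nitrile would keep the number this low remains open. Nothing shown here explains why these groups differ.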